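Swapping methoxy for methyl on the amide-bound phenyl

The source may report more compounds than this note shows. Statements on the series, on what has been measured and on what is new or still open speak of the compounds shown alone.

Compound 3 `COc1ccc(N(C)C(=O)c2c(O)c3cc(SC)ccc3n(C)c2=O)cc1` is one of three compounds tested in a functional assay on the whole organism for inhibition, with Mus musculus as the target, at a dose of 32 mg/kg by the oral route; on this read-out higher numbers stand for more inhibition at the one dose given (going by the name of the read-out) and lower numbers for less inhibition. There compound 3 gives 100%, level with compound 1 `CSc1ccc2c(c1)c(O)c(C(=O)N(C)c1ccccc1)c(=O)n2C`, which gives 100%, and together they stand highest of the three. Compound 2 `CSc1ccc2c(c1)c(O)c(C(=O)N(C)c1ccccn1)c(=O)n2C`, carrying pyridin-2-yl in place of phenyl, gives 65%; the step of a number 35 percentage points lower from compound 1 to compound 2 (beyond the scatter) and the step of a number 35 percentage points higher from compound 2 to compound 3 (beyond the scatter) are both beyond the scatter, whereas no change at the digits printed from compound 1 to compound 3 (within the scatter) lies within it.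

Compound 4 `CSc1ccc2c(c1)c(O)c(C(=O)N(C)c1ccc(C)cc1)c(=O)n2C` differs from compound 3 by methyl in place of methoxy on an aromatic carbon. Going by the values given here, the only step that speaks to this position is the one from compound 1 to compound 3, where adding methoxy changed nothing beyond the scatter in this assay. Methyl in place of methoxy is a smaller change still, and the large movements seen so far came only from exchanging phenyl for pyridin-2-yl. No change beyond the scatter is therefore expected in this assay, and the expected step is a number 5 percentage points lower from compound 3 to compound 4 (within the scatter). Compound 4 is accordingly estimated at 95%, with a range from 80% to 100%, because compound 3 gives 100% and the number for compound 4 is expected to be level with it.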

Compound 4, a percentage reported as inhibition, in the whole organism at one dose (the size of the read-out at that dose, not a potency): 100%
For compound 4 the middle estimate is 5 percentage points below the measured one; measured number inside the range.
By their numbers in this assay, from the lowest: compound 2; then compounds 1, 3 and 4 (each within the scatter of the next).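

Methyl in place of methoxy on the phenyl ring gives no change at the digits printed from compound 3 to compound 4 (within the scatter) in this assay, and methyl in place of hydrogen gives no change at the digits printed from compound 1 to compound 4 (within the scatter), so hydrogen, methoxy and methyl at this aromatic carbon cannot be told apart on this read-out. Methoxy counts one hydrogen-bond acceptor and methyl none, so that acceptor is not needed to hold the number at this one dose. Exchanging pyridin-2-yl for 4-methylphenyl gives a number 35 percentage points higher from compound 2 to compound 4 (beyond the scatter), the same size as the step to the 4-methoxyphenyl compound, so among these four compounds only compound 2, with pyridin-2-yl, stands apart.

Nothing at hand gives a reason for the flat response at this position or for the gap at pyridin-2-yl. Still open, from the compounds shown here alone, is whether an amine, a carboxylic acid or a longer chain on this same carbon would hold the number in this assay, and whether compound 1, compound 3 and compound 4 would separate at a lower dose.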